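Swapping phenyl for methyl on the hydrazone carbon

The source may report more compounds than this note shows. Statements on the series, on what has been measured and on what is new or still open speak of the compounds shown alone.

Compound 1 `O=C(N/N=C\c1cccc(O)c1)Nc1nnc(COc2ccc3ccccc3c2)o1`: 300 mg/kg
Compound 2 `Cc1ccc(/C=N\NC(=O)Nc2nnc(COc3ccc4ccccc4c3)o2)cc1`: 300 mg/kg
Compound 3 `O=C(N/N=C(/c1ccccc1)c1ccc(O)cc1)Nc1nnc(COc2ccc3ccccc3c2)o1`: 300 mg/kg

All three share one core and differ only at the carbon with a double bond to nitrogen. Within the data shown here, in a functional assay on the whole organism (strain Swiss albino) with Mus musculus as the target, in the maximal electroshock model, with a stated time of 4 h (a lower number here means that less compound is needed, a higher number that more compound is needed for the effect), compound 3 gives 300 mg/kg, level with compounds 1 and 2, and the single measured step, no change at the digits printed from compound 1 to compound 2 (within the scatter), left the dose unchanged. Compound 4 `C/C(=N/NC(=O)Nc1nnc(COc2ccc3ccccc3c2)o1)c1ccc(O)cc1` differs from compound 3 in one place: methyl in place of phenyl on a carbon with a double bond to nitrogen. Among the measured compounds shown here, no measured step removes a phenyl from this carbon, so the step from compound 1 to compound 2 bears only loosely, showing that a change at this carbon has so far not moved the dose. Compound 4 is therefore expected at 300 mg/kg (range 150 mg/kg to 600 mg/kg), and the expected step of no change at the digits printed from compound 3 to compound 4 (within the scatter) should stay within the scatter.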

Compound 4, minimum effective dose: 300 mg/kg
Estimate against measurement, compound 4: no gap at the digits printed, and the stated range covers the measured number.
By their numbers in this assay, from the lowest: compounds 1, 2, 3 and 4 (each within the scatter of the next).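

Methyl in place of phenyl on a carbon with a double bond to nitrogen gives no change at the digits printed from compound 3 to compound 4 (within the scatter) in this assay, so this is the first measured case where taking a phenyl off this carbon leaves the dose where it was. The broader swaps of the group on the amide-type nitrogen read the same, with no change at the digits printed from compound 2 to compound 4 (within the scatter) and no change at the digits printed from compound 1 to compound 4 (within the scatter) on record. Nothing measured here explains this flat result.

From the compounds shown here alone, whether any change at this carbon can shift the dose stays open. An amine, a carboxylic acid or a longer chain in place of methyl could still answer that.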